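The compounds below may be only part of what the source reports. "The series", "measured", "known", "first", "only" and "open" are said of these compounds alone.

Of the compounds shown here, two have so far been measured in a functional assay on K562 cells (Homo sapiens) for antiproliferative activity, read by MTT assay, with a stated time of 48 h; a lower number here means a stronger inhibitor, a higher number a weaker inhibitor. Compound 1, `CC1(C)CCC(C)(C)c2cc(NC(=O)c3ccc(C(=O)OCCOC(=O)c4ccc(OCc5c(-c6ccccc6)no[n+]5[O-])cc4)cc3)ccc21`, reaches only a limit of the assay, recorded as > 1000000 nM. That value is the limit at which one of the two values sits, (the limit of > 1000000 nM in this assay, at which 1 of the 2 values shown sits), and it is not a number. Compound 2, `CC1(C)CCC(C)(C)c2cc(NC(=O)c3ccc(C(=O)NCC(=O)OCc4c(-c5ccccc5)no[n+]4[O-])cc3)ccc21`, gives 7120 nM in this assay, and this is the only actual number shown. Compound 2 therefore stands alone as the single measured potency, with nothing of equal standing to compare it against.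

Compound 3, `C[C@H](NC(=O)c1ccc(C(=O)Nc2ccc3c(c2)C(C)(C)CCC3(C)C)cc1)C(=O)OCc1c(-c2ccccc2)no[n+]1[O-]`, differs from compound 2 in one place: methyl in place of hydrogen on a saturated chain carbon bound to an amide-type nitrogen and a carbonyl carbon. For the measured compounds named here, no step between two measured compounds is available to show what such a change does in this assay, so the expectation rests on the structural change alone. A single methyl entering on a saturated chain carbon bound to an amide-type nitrogen and a carbonyl carbon is expected to move the number little, and the step from compound 2 to compound 3 is expected to be a 1.0-fold lower number from compound 2 to compound 3 (0.01 log units; within the scatter), within the usual scatter. Compound 3 is expected to give about 7000 nM, with a range from 3000 nM to 16000 nM.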

Compound 3, half-maximal inhibitory concentration: 60400 nM
Estimate against measurement, compound 3: 8.6-fold (0.94 log units) below; measured number outside the range, above it.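

In this assay the carbon bound to an amide-type nitrogen and a carbonyl carbon proves sensitive to substitution, as methyl in place of hydrogen at this place brings an 8.5-fold higher number from compound 2 to compound 3 (0.93 log units; beyond the scatter) and so a weaker inhibitor. The earlier compounds shown here could not show this, as they offered no pair differing in one place, whereas this single step shows that one added carbon on the saturated chain can move the number beyond the usual scatter. The measurements shown do not explain why the number rises.

On these data alone, it remains open whether a longer chain such as ethyl, or a hydroxymethyl group or an amine on the same carbon, would shift the number further than methyl, less far or in the opposite direction. As far as these compounds go, it is also open whether the methyl arranged in the mirror-image form at this carbon would give the same result as in compound 3, and whether the same change would have a similar effect on a different part of the chain.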